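A few compounds are considered here, and "the series" means these few. Any claim that something is new, unique, unknown or untested is made for them only; others in the source may bear on it.

The measured compounds and their numbers:

Compound 1 `O=c1cc(-c2ccccc2)oc2cc(OCc3ccccc3)c(OCCCCN3CCCCC3)c(O)c12` gives 2400 nM in a functional assay on HepG2 cells (Homo sapiens) for antiproliferative activity, read by MTT assay, with a stated time of 48 h; on this read-out higher numbers stand for weaker inhibition and lower numbers for stronger inhibition.
Compound 2 `O=c1cc(-c2ccccc2)oc2cc(OCc3ccccc3)c(OCCCN3CCCC3)c(O)c12` gives 4200 nM in this assay.
Compound 3 `COc1cc2oc(-c3ccccc3)cc(=O)c2c(O)c1OCCCN1CCCC1` gives 4300 nM in this assay.

Compound 2 stands second highest of the three numbers. Its nearest neighbour is compound 3, reached by a 1.0-fold higher number from compound 2 to compound 3 (0.01 log units; within the scatter), and its furthest is compound 1, from which it is separated by a 1.8-fold higher number from compound 1 to compound 2 (0.24 log units; within the scatter); neither gap is more than the assay's own scatter, so the three compounds cannot be ranked against one another on these numbers.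

The step from compound 2 to compound 4 `CN(C)CCCOc1c(OCc2ccccc2)cc2oc(-c3ccccc3)cc(=O)c2c1O` is dimethylamino in place of pyrrolidin-1-yl on a saturated chain carbon, three bonds along the chain from an oxygen on an aromatic ring. Among the compounds with values here, the only measured step that touches the amine end of the chain is a 1.8-fold higher number from compound 1 to compound 2 (0.24 log units; within the scatter), where a change of the ring amine together with the chain gave a number within the scatter. The step of a 1.0-fold higher number from compound 2 to compound 3 (0.01 log units; within the scatter) concerns a different place and does not speak to an amine change. On that basis no step beyond the scatter is expected in this assay, in either direction, and the expected step is a 1.1-fold higher number from compound 2 to compound 4 (0.03 log units; within the scatter).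

Compound 4 is therefore estimated at 4500 nM in this assay, with a range from 2000 nM to 10000 nM.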

Compound 4, half-maximal inhibitory concentration: 2200 nM
Compound 4: middle estimate off by 2.0-fold (0.31 log units), on the high side, within the range that was stated.
By their numbers in this assay, from the lowest: compounds 4, 1, 2 and 3 (each within the scatter of the next).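

In this assay, within the data shown here, the new result is the first reading of a change at the amine end alone, with the 3-carbon chain name unchanged: going from 3-(pyrrolidin-1-yl)propyl to 3-(dimethylamino)propyl gives a 1.9-fold lower number from compound 2 to compound 4 (0.28 log units; within the scatter), so opening the amine to a group with no ring does not move the number beyond the scatter. The second new comparison, with the piperidin-1-yl compound on its longer chain, gives a 1.1-fold lower number from compound 1 to compound 4 (0.04 log units; within the scatter) and also stays within the scatter, which means that among these compounds a ring on the amine is not required for a number of this size, and no ranking of the amines can be drawn from them. Nothing at hand bears on why these amines read alike.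

The compounds shown leave open whether a morpholine ring, or a primary amine, at the end of the same chain would also stay within the scatter of these numbers. They also leave open whether a carboxylic acid in place of the amine would keep the number, and how dimethylamino behaves on a longer chain.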